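A few compounds are considered here, and "the series" means these few. Any claim that something is new, unique, unknown or untested is made for them only; others in the source may bear on it.

Compound 3 `CC(=O)Nc1cccc(Oc2nc(NCC3CCOCC3)n3ncc(-c4ccc(C(=O)NC5CC5)c(C)c4)c3n2)c1` and compound 2 `O=C(NC1CC1)c1ccc(-c2cnn3c(NCC4CCOCC4)nc(NC4CCCC4)nc23)cc1F` share a core with compound 1 `CN(c1nc(NCC2CCOCC2)n2ncc(-c3ccc(C(=O)NC4CC4)c(F)c3)c2n1)C1CCCCC1`. In a functional assay on OVCAR-3 cells (Homo sapiens) for antiproliferative activity (on this read-out lower numbers stand for stronger inhibition of growth and higher numbers for weaker inhibition of growth), compound 1 gives "not determined" (no result reported), so no result exists for it there. In this assay compound 3 gives 1200 nM, and compound 2 gives 1700 nM; the two numbers lie within the usual scatter of each other, so neither can be set above the other. Compound 4 `Cc1cc(-c2cnn3c(NCC4CCOCC4)nc(Nc4ccccc4F)nc23)ccc1C(=O)NC1CC1` carries (2-fluorophenyl)amino in place of 3-acetamidophenoxy on an aromatic carbon, a (2-fluorophenyl)amino in place of 3-acetamidophenoxy on an aromatic carbon. Among the compounds with values here, no measured pair shows the effect of such an exchange, so the step from compound 3 to compound 4 in this assay is expected to stay within the scatter, with perhaps a slight lowering, a 1.2-fold lower number from compound 3 to compound 4 (0.08 log units; within the scatter). Compound 4 is therefore estimated at 1000 nM, within a range of 300 nM to 4000 nM.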

Compound 4, concentration for 50% growth inhibition: 190 nM
Compound 4: the middle estimate sits 5.3-fold (0.72 log units) above what was measured, and the stated range ends above it.
By their numbers in this assay, from the lowest: compound 4; then compounds 3 and 2 (each within the scatter of the next).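

In this assay, the group on the aromatic carbon between two ring nitrogen atoms can shift the read-out: (2-fluorophenyl)amino in place of 3-acetamidophenoxy gives a 6.3-fold lower number from compound 3 to compound 4 (0.80 log units; beyond the scatter), the only step shown here between compounds differing in one place. Nothing available accounts for this step. The exchange alters both the ring's substituent and the atom linking it to the core, so the compounds shown do not separate these two parts. Going by these compounds, whether a plain phenylamino or a benzylamino group would give a similar number remains open.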